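A few compounds are considered here, and "the series" means these few. Any claim that something is new, unique, unknown or untested is made for them only; others in the source may bear on it.

Measured compounds:
Compound 1 `Cc1nc(N)c2c(-c3cccs3)cn([C@@H]3O[C@H](CO)[C@@H](O)[C@H]3O)c2n1`. In a functional assay on K562 cells (Homo sapiens), read by MTT assay, with a stated time of 72 h (a lower number here means a stronger inhibitor, a higher number a weaker inhibitor), compound 1 gives > 20000 nM, which is a limit of the assay and not a number.
Compound 2 `COc1nc(N)nc2c1c(-c1cccs1)cn2[C@@H]1O[C@H](CO)[C@@H](O)[C@H]1O`. In this assay compound 2 gives > 20000 nM, again only a limit.
Compound 3 `C#Cc1cn([C@@H]2O[C@H](CO)[C@@H](O)[C@H]2O)c2nc(C)nc(N)c12`. In this assay compound 3 gives > 20000 nM, also a limit.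

Compound 1 and compound 2 differ in their cores, and that difference is not broken down here. Compound 3 arises from compound 1 by ethynyl in place of thiophen-2-yl on an aromatic carbon. The step that the two limits leave unreadable from compound 1 to compound 3 stays unreadable because of the limit of > 20000 nM in this assay, at which 3 of the 3 values shown sit. The not yet measured compound 4 `C#Cc1cn([C@@H]2O[C@H](CO)[C@@H](O)[C@H]2O)c2nc(N)nc(OC)c12` stands to compound 2 as compound 3 stands to compound 1, through the same change, (ethynyl in place of thiophen-2-yl on an aromatic carbon), at the same place. The expectation for this step is a step that the limit leaves unreadable from compound 2 to compound 4, resting on (the limit of > 20000 nM in this assay, at which 3 of the 3 values shown sit). Compound 4 is therefore estimated at 30000 nM. Its expected range runs from 10000 nM to 100000 nM, with a limit rather than a number the most likely report.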

Compound 4, half-maximal inhibitory concentration: > 20000 nM
Compound 4 ended at the assay's limit; the forecaster's own chance of this, stated with the estimate: 85%; the middle value is on the limit's open side.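

No size can be read for the step from compound 2 to compound 4, as both compounds give only a limit: the limit of > 20000 nM in this assay, at which 4 of the 4 values shown sit.

The compounds shown leave open whether ethynyl and thiophen-2-yl differ at all in inhibition on either core.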